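Shortening a polyether chain on a shared ester core

The source may hold more compounds than are shown below. What is called first, only, known or untested is meant among the compounds shown, and "the series" means these compounds.

Of the compounds shown here, three have been measured for cytotoxicity, and a fourth awaits testing. Compound 1 `COCCOCCOCCOCCOCCOCCOCCOCCOCCOCCOC(=O)Oc1c(C(C)C)cccc1C(C)C` and compound 3 `COCCOCCOCCOCCOCCOCCOCCOCCOCCOCCOCC(=O)Oc1c(C(C)C)cccc1C(C)C` carry related but not identical cores; the difference between the two cores is not broken down here. In an ADME assay on L929 cells (Mus musculus) for cytotoxicity, read by MTT assay, with a stated time of 24 h (on this read-out higher numbers stand for an effect only at larger amounts of compound and lower numbers for an effect already at smaller amounts), compound 1 gives 420000 nM, while compound 3 gives 490000 nM. Compound 2 `COCCOCCOCCOCCOCCOCCOCCOC(=O)Oc1c(C(C)C)cccc1C(C)C` arises from compound 1 by a single change, (hydrogen in place of (2-(2-methoxyethoxy)ethoxy)methyl on a saturated chain carbon bound to an oxygen on a saturated carbon), and this change brought a 3.8-fold lower number from compound 1 to compound 2 (0.58 log units; beyond the scatter), so that in this assay compound 2 gives 110000 nM. Compound 4 `COCCOCCOCCOCCOCCOCCOCCOCC(=O)Oc1c(C(C)C)cccc1C(C)C` has not yet been measured. It arises from compound 3 by the same change, (hydrogen in place of (2-(2-methoxyethoxy)ethoxy)methyl on a saturated chain carbon bound to an oxygen on a saturated carbon), made at a place described in the same words. Since this change has been seen only once among the compounds here, the expectation for compound 4 rests on that single step alone, and a step of similar size is expected, namely a 3.8-fold lower number from compound 3 to compound 4 (0.58 log units; beyond the scatter), because compound 3 sits at 490000 nM. Compound 4 is therefore estimated at 130000 nM in this assay, probably falling between 50000 nM and 350000 nM.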

Compound 4, half-maximal effective concentration: 120000 nM
Compound 4: the middle estimate sits 1.1-fold (0.03 log units) above what was measured, within the range that was stated.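

In this assay, putting hydrogen in place of (2-(2-methoxyethoxy)ethoxy)methyl brought a 4.1-fold lower number from compound 3 to compound 4 (0.61 log units; beyond the scatter), and this step matches the earlier one on the other core: the same change on two cores in this assay, a 3.8-fold lower number (0.58 log units; beyond the scatter) from compound 1 to compound 2 and a 4.1-fold lower number (0.61 log units; beyond the scatter) from compound 3 to compound 4, 1.1-fold (0.03 log units) apart, within the scatter of two such steps On these two cores, then, the same shortening of the chain goes with a step of about the same size, so the core difference shown here did not alter what the change did to the number. This rests on just two pairs of closely related compounds, however, and it shows neither that the step would carry over to a more different core nor why removing this part of the chain lowers the number.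

The compounds shown leave open how the number moves with a still shorter chain or a longer chain on either core. They also leave open whether a chain carrying an amine or a carboxylic acid would follow the same step.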